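A few compounds are considered here, and "the series" means these few. Any claim that something is new, unique, unknown or untested is made for them only; others in the source may bear on it.

In a physicochemical assay for solubility, read by HPLC, measured as thermodynamic solubility, with a stated time of 24 h, at pH 1.5 (on this read-out higher numbers stand for higher solubility and lower numbers for lower solubility), compound 1 `CCCc1ccc(NC(=O)COc2cc(C)nc3ccc(OC)cc23)cc1` gives 260000 nM, compound 2 `CCc1ccc(NC(=O)COc2cc(C)nc3ccc(OC)cc23)cc1` gives 790000 nM, and compound 3 `COc1ccc2nc(C)cc(OCC(=O)Nc3ccc4c(c3)CCCC4)c2c1` gives 90000 nM.

Compound 1 stands second highest of the three: compound 2 sits above it and compound 3 below it, both beyond the scatter. Among the compounds with values here, the one step measured in a single place, a 3.0-fold higher number from compound 1 to compound 2 (0.48 log units; beyond the scatter), concerns the chain only and does not bear directly on the change to compound 4 `COc1ccc2nc(C)cc(OCC(=O)Nc3ccc4c(c3)CCC4)c2c1`, which is 2,3-dihydro-1H-inden-5-yl in place of 4-propylphenyl on an amide-type nitrogen. Compound 3, the measured compound nearest in structure to compound 4, shows a lower number than compound 1 in this assay. A modest decrease is therefore expected, a 1.7-fold lower number from compound 1 to compound 4 (0.24 log units; within the scatter). Compound 4 is estimated at 150000 nM, within 60000 nM to 400000 nM.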

Compound 4, solubility: 240000 nM
The estimate for compound 4 lay 1.6-fold (0.20 log units) below the measured number; the range from low to high includes it.
By their numbers in this assay, from the lowest: compound 3; then compounds 4 and 1 (each within the scatter of the next); then compound 2.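

In this assay, 2,3-dihydro-1H-inden-5-yl in place of 4-propylphenyl on the amide-type nitrogen leaves the reading within the scatter, a 1.1-fold lower number from compound 1 to compound 4 (0.03 log units; within the scatter), with both groups counting 9 carbon heavy atoms. Set against 4-ethylphenyl, the same group gives a step beyond the scatter, a 3.3-fold lower number from compound 2 to compound 4 (0.52 log units; beyond the scatter). Nothing given here accounts for these readings.

The compounds shown leave open how an amine or a carboxylic acid on the aromatic ring at this position would read at this pH. They also leave open how a butyl chain in place of the propyl of compound 1 would read.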